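Fluoro for Methyl: Expecting a Small Step

This account rests on a few compounds, and the source may have more. Where it says the series, first, only, none or still open, it means among the compounds named here.

Compound 1 `O=c1[nH]cc(S(=O)(=O)Nc2ccccc2-c2cn(-c3ccccc3Cl)nn2)c(=O)[nH]1` gives 2240 nM in a functional assay on HepG2 cells (Homo sapiens) for antiproliferative activity, read by MTT assay, with a stated time of 24 h; a higher number here means a weaker inhibitor, a lower number a stronger inhibitor.
Compound 2 `Cc1cccc(-n2cc(-c3cccc(NS(=O)(=O)c4c[nH]c(=O)[nH]c4=O)c3)nn2)c1` gives 7050 nM in this assay.

Of the two numbers measured in this assay, compound 2 holds the highest, that is, the weaker inhibition. For the measured compounds named here, its nearest neighbour, compound 1, sits below it by a gap that is beyond the usual scatter, though the two structures differ in more than one place, so no single step between them can be read.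

Compound 3 `O=c1[nH]cc(S(=O)(=O)Nc2cccc(-c3cn(-c4cccc(F)c4)nn3)c2)c(=O)[nH]1` is the next compound to be tested. It differs from compound 2 in one place only: fluoro in place of methyl on an aromatic carbon, so that a 3-methylphenyl becomes a 3-fluorophenyl. Going by the values given here, no measured pair in this set isolates such a swap, so there is no step to lean on. Both groups are single heavy atoms carrying no donor or acceptor, and the change is expected to move the number little, most likely within the scatter, with a mild lean towards a lower value. For compound 3 the estimate in this assay is 6000 nM, with a range from 2000 nM to 18000 nM. The step this implies, a 1.2-fold lower number from compound 2 to compound 3 (0.07 log units; within the scatter), is an expectation rather than a measured result.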

Compound 3, half-maximal inhibitory concentration: > 20000 nM
Compound 3 ended at the assay's limit; the forecaster's own chance of this, stated with the estimate: 5%; middle value at least 3.3-fold (0.52 log units) from the limit.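

For the compounds shown here, compounds 1 and 2 differ in more than one place, so no step could be read between them, and the swap of methyl for fluoro gives the first reading in one place. On the ring that carries the 3-methylphenyl of compound 2, fluoro in place of methyl gives an at least 2.8-fold higher number from compound 2 to compound 3 (0.45 log units; beyond the scatter) in this assay, which shows that activity at this position responds to an exchange of one heavy atom for another, even though neither group carries a hydrogen-bond donor or acceptor and neither bears a net charge. In this assay compound 3 gives > 20000 nM, which is a limit of the assay and not a number: the limit of > 20000 nM in this assay, at which 1 of the 3 values shown sits.

From the compounds shown here alone, how far compound 3 lies past that limit stays open, so the full size of the step is unknown, and one swap at one position cannot show a trend. Going by these compounds, whether an unsubstituted phenyl, or a methoxy or an amine at the same place, would track with the methyl of compound 2 or with the fluoro of compound 3 also remains open.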